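The compounds below may be only part of what the source reports. "The series", "measured", "known", "first", "only" and "open" are said of these compounds alone.

Compound 1 `Cc1cc(NCc2ccccn2)n2ncc(Br)c2n1` is the most soluble of the three compounds measured in a physicochemical assay for solubility, read by HPLC, using the shake flask method, measured as kinetic solubility, with a stated time of 2 h, at pH 7.4 (a higher number here means a more soluble compound, a lower number a less soluble compound), where compound 1 gives 89300 nM. Compound 2 `Cc1cc(NCCCc2ccccn2)n2nc(C)c(-c3ccccc3)c2n1` gives 5900 nM in this assay, and compound 3 `Cc1cc(NCc2c[nH]cn2)n2nc(C)c(-c3ccccc3)c2n1` gives 14600 nM. Going by the values given here, the only single-point step recorded, a 2.5-fold higher number from compound 2 to compound 3 (0.39 log units; beyond the scatter), concerns the group on the saturated chain carbon and does not touch the position altered here. Compound 4 `Cc1cc(NCc2ccccn2)n2ncc(-c3ccc(F)c(Cl)c3)c2n1` differs from compound 1 by 3-chloro-4-fluorophenyl in place of bromo on an aromatic carbon, a change that leaves the chain and the shared core untouched. Among the compounds with values here, no measured step covers this exchange; what the numbers show is that compound 2 and compound 3, which carry a phenyl on the corresponding aromatic carbon together with a methyl on the core, both sit well beneath compound 1 in this assay. On that basis the account expects a downward step, an 11-fold lower number from compound 1 to compound 4 (1.05 log units; beyond the scatter), for compound 4, with considerable uncertainty since the comparison is indirect. Compound 4 is therefore estimated at 8000 nM in this assay, within a range from 2000 nM to 30000 nM.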

Compound 4, solubility: < 5000 nM
Compound 4 gave a limit, no number (the forecaster's own chance of this, stated with the estimate: 5%); middle value at least 1.6-fold (0.20 log units) from the limit.
By their numbers in this assay, from the lowest: compound 2; then compound 3; then compound 1. At a limit, below all of these: compound 4.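

Going by these compounds alone, replacing bromo with 3-chloro-4-fluorophenyl on this aromatic carbon, with the chain and the shared core left unchanged, gives the first direct reading of this exchange in this assay: an at least 17-fold lower number from compound 1 to compound 4 (1.25 log units; beyond the scatter). Compound 2 and compound 3 carry a phenyl on the corresponding carbon only together with a methyl on the core and a different group on the chain, so they could not isolate this position. Compound 4 stands at a limit of the assay, not at a number: the limit of < 5000 nM in this assay, at which 1 of the 4 values shown sits.

The compounds shown leave open how far the chlorine and fluorine on the ring contribute to this step, and how a plain phenyl, a morpholine or a carboxylic acid on this carbon would read in this assay. On these data alone, how far compound 4 lies past its limit also stays open.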